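Adding Fluoro to a Weak Inhibitor

This account rests on a few compounds, and the source may have more. Where it says the series, first, only, none or still open, it means among the compounds named here.

Three compounds have been measured:
compound 1, `Cc1ccc(-c2ccnc(C(=O)Nc3ccc(Oc4ccnc5[nH]ccc45)cc3)n2)cc1`, 6410 nM
compound 2, `O=C(Nc1ccc(Oc2ccnc3[nH]ccc23)cc1)c1cc(-c2ccc(F)cc2)ncn1`, 15900 nM
compound 3, `O=C(Nc1ccc(Oc2ccnc3[nH]ccc23)cc1)c1cc(-c2ccccc2)ncn1`, 20 nM

All three were tested in a functional assay on MCF7 cells (Homo sapiens) for cytotoxicity, read by MTT assay, with a stated time of 72 h; a lower number here means a stronger inhibitor, a higher number a weaker inhibitor. Compound 3 gives 20 nM, compound 2 gives 15900 nM, and compound 1 gives 6410 nM. Compound 3 and compound 2 differ in one place: fluoro in place of hydrogen on an aromatic carbon. That single change produced an 800-fold higher number from compound 3 to compound 2 (2.90 log units; beyond the scatter). The difference between the core of compound 1 and the core of compound 3 is not broken down here.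

Compound 4, `Cc1ccc(-c2ccnc(C(=O)Nc3ccc(Oc4ccnc5[nH]ccc45)c(F)c3)n2)cc1`, has not yet been measured. It differs from compound 1 in one place: fluoro in place of hydrogen on an aromatic carbon. For the measured compounds named here, this is the same kind of change as the one between compound 3 and compound 2, but not the same: in the measured pair the fluoro stands para to a large group, whereas in compound 4 it stands ortho to a large group and meta to a large group. Because an 800-fold higher number from compound 3 to compound 2 (2.90 log units; beyond the scatter) was seen, a shift toward a higher number is expected here too, namely a 3.1-fold higher number from compound 1 to compound 4 (0.49 log units; beyond the scatter), kept smaller than the precedent given the different place. Compound 4 is therefore expected to give about 20000 nM, most likely between 5000 nM and 100000 nM, with a fair chance that only a limit is reported.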

Compound 4, half-maximal inhibitory concentration: 7170 nM
Beside the measured number, compound 4's estimate is 2.8-fold (0.45 log units) above it; measured number inside the range.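

In this assay, fluoro in place of hydrogen gave a 1.1-fold higher number from compound 1 to compound 4 (0.05 log units; within the scatter), so on the core of compound 1 the numbers with and without fluoro cannot be told apart, and the large step seen on the other core did not carry over: the same change on two cores in this assay, an 800-fold higher number (2.90 log units; beyond the scatter) from compound 3 to compound 2 and a 1.1-fold higher number (0.05 log units; within the scatter) from compound 1 to compound 4, 710-fold (2.85 log units) apart, beyond the scatter of two such steps

This does not show whether the core or the place of the fluoro accounts for the gap, as the two pairs differ in both and nothing shown separates them. Nor does it show that fluoro makes no difference anywhere on the core of compound 1, as compound 4 covers a single place, on a six-membered aromatic ring of carbon only, ortho to a large group and meta to a large group.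

The compounds shown leave open what fluoro would do at the place it holds in compound 2 if set on the core of compound 1, and at the place it holds in compound 4 if set on the core of compound 3. They also leave open how chloro, methoxy or an amine would read at either place.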